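The source may hold more compounds than are shown below. What is called first, only, known or untested is meant among the compounds shown, and "the series" means these compounds.

Three compounds that share one core and differ only in the group on a carbon with a double bond to nitrogen have been measured in a functional assay on A549 cells (Homo sapiens) for cytotoxicity, read by MTT assay, with a stated time of 72 h; a lower number here means a stronger inhibitor, a higher number a weaker inhibitor. Compound 1 `COc1cc2ncnc(Nc3ccc(F)c(Cl)c3)c2cc1NC(=O)N/N=C/c1cccc(Br)c1`, with 3-bromophenyl, gives 28100 nM. Compound 2 `COc1cc2ncnc(Nc3ccc(F)c(Cl)c3)c2cc1NC(=O)N/N=C/c1ccc(C#N)cc1`, with 4-cyanophenyl, gives 32200 nM. Compound 3 `COc1ccc(/C=N/NC(=O)Nc2cc3c(Nc4ccc(F)c(Cl)c4)ncnc3cc2OC)cc1`, with 4-methoxyphenyl, gives 28100 nM, level with compound 1 and within the scatter of compound 2.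

The next compound, compound 4 `COc1cc2ncnc(Nc3ccc(F)c(Cl)c3)c2cc1NC(=O)N/N=C/c1ccc(O)c(Br)c1`, carries 3-bromo-4-hydroxyphenyl in place of 4-methoxyphenyl at that same carbon: 3-bromo-4-hydroxyphenyl in place of 4-methoxyphenyl on a carbon with a double bond to nitrogen. All three measured steps bear on this exchange. The change is a 1.1-fold higher number from compound 1 to compound 2 (0.06 log units; within the scatter), then no change at the digits printed from compound 1 to compound 3 (within the scatter), and finally a 1.1-fold lower number from compound 2 to compound 3 (0.06 log units; within the scatter), and each of these lies within the scatter. Swapping this group has so far left the number essentially unmoved, although the hydroxy group of compound 4 appears in none of the measured compounds, so the data do not test it directly. The expected change, a 1.1-fold lower number from compound 3 to compound 4 (0.03 log units; within the scatter), is therefore no step beyond the scatter, with no direction favoured. For compound 4 the estimated value is 26000 nM, with an expected range from 12000 nM to 50000 nM.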

Compound 4, half-maximal inhibitory concentration: 28600 nM
The estimate for compound 4 lay 1.1-fold (0.04 log units) below the measured number; the measured number falls inside the stated range.
By their numbers in this assay, from the lowest: compounds 1, 3, 4 and 2 (each within the scatter of the next).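

Within the data shown here, the hydroxy group, absent from the earlier compounds, can now be read directly: in this assay, adding it to the 3-bromophenyl group gives a 1.0-fold higher number from compound 1 to compound 4 (0.01 log units; within the scatter), so this exchange on the aromatic ring leaves the number within the scatter. The other two comparisons agree, with a 1.0-fold higher number from compound 3 to compound 4 (0.01 log units; within the scatter) and a 1.1-fold lower number from compound 2 to compound 4 (0.05 log units; within the scatter), which extends the flat picture at the carbon with a double bond to nitrogen to a group with a hydrogen-bond donor, and all four aryl groups shown remain indistinguishable in this assay. No supporting data are available to explain this result.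

From the compounds shown here alone, all four compounds carry a six-membered aromatic ring of carbon at this place, so it remains open whether a simple alkyl chain there, or an amine or a carboxylic acid on the ring, would move the number beyond the scatter. The shared core is also the same throughout, so these compounds leave open how the number would respond to a change anywhere else in the structure.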